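Methoxy for chloro on a shared spirocyclic core

A few compounds are considered here, and "the series" means these few. Any claim that something is new, unique, unknown or untested is made for them only; others in the source may bear on it.

In an ADME assay on L02 cells (Homo sapiens) for antiproliferative activity, read by MTT assay, with a stated time of 48 h (on this read-out lower numbers stand for stronger inhibition and higher numbers for weaker inhibition), compound 1, `Cc1cc(C)cc(-n2nncc2CN2C(=O)C3(C(C#N)=C(N)Oc4c3c3nc5ccccc5nc3c3ccccc43)c3ccccc32)c1`, gives only a limit of > 50000 nM and no number. Compound 2, `N#CC1=C(N)Oc2c(N)cc3nc4ccccc4nc3c2C12C(=O)N(Cc1cnnn1-c1ccccc1Cl)c1ccccc12`, likewise reaches only the limit of > 50000 nM in this assay. Among the measured compounds shown here, compound 2 therefore stands at the same boundary as the only other compound with a value, as the limit of > 50000 nM in this assay, at which 2 of the 2 values shown sit, records: neither gives a measurable concentration within the tested range.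

Compound 3, `COc1ccccc1-n1nncc1CN1C(=O)C2(C(C#N)=C(N)Oc3c(N)cc4nc5ccccc5nc4c32)c2ccccc21`, carries the same core as compound 2 and differs from it by methoxy in place of chloro on an aromatic carbon, the substituted ring being 2-methoxyphenyl rather than 2-chlorophenyl. For the measured compounds named here, no step between two measured compounds exists here, so the size of the step from compound 2 to compound 3 in this assay cannot be read from a measured pair; the expectation is that it remains within the scatter, and compound 3 is expected to sit at or beyond the limit, with the step from compound 2 estimated as a step that the limit leaves unreadable from compound 2 to compound 3. Compound 3 is thus expected to give about 60000 nM, within a range from 30000 nM to 150000 nM, and most likely the assay will again report only a limit.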

Compound 3, half-maximal inhibitory concentration: > 50000 nM
Compound 3: a limit, no number; the forecaster's own chance of this, stated with the estimate: 85%; the middle value does not contradict the limit.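

In this assay compound 2 and compound 3 are both recorded only as limits, not numbers, so the change from 2-chlorophenyl to 2-methoxyphenyl gives no readable step. The compounds shown leave open how they would rank against one another in this read-out, since all of them sit at one boundary: the limit of > 50000 nM in this assay, at which 3 of the 3 values shown sit.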